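The compounds below may be only part of what the source reports. "The series", "measured", "known", "first", "only" and "open" are said of these compounds alone.

Compound 1 `NC(=O)C[C@H](NC(=O)CN(c1nc(Cl)nc2[nH]cnc12)C1CC1)C(=O)O` gives 43.1% in a functional assay on the whole organism (Tail, strain ICR) with Mus musculus as the target, in the tail flick test, with a stated time of 60 min, at a dose of 25 umol/kg by the oral route; on this read-out lower numbers stand for a weaker effect and higher numbers for a stronger effect at the one dose given.
Compound 2 `O=C(CN(c1ncnc2c1ncn2C1CCCCO1)C1CC1)N[C@@H](CC(=O)OCc1ccccc1)C(=O)OCc1ccccc1` gives 38.2% in this assay.
Compound 3 `NC(=O)CC[C@H](NC(=O)CN(c1nc(Cl)nc2[nH]cnc12)C1CC1)C(=O)OCc1ccccc1` gives 33.1% in this assay.

Compound 1 has the highest of the three numbers, but compound 2 lies within the scatter of it, and so does compound 3, so none of the three can be set apart from the others. Compound 4 `C[C@H](NC(=O)CN(c1nc(Cl)nc2[nH]cnc12)C1CC1)C(=O)O` has not yet been measured. It differs from compound 1 in one place: hydrogen in place of carbamoyl on a saturated chain carbon, two bonds along the chain from an amide-type nitrogen and a carbonyl carbon. Going by the values given here, no two measured compounds differ in a single place, so no measured step is at hand to guide the size of this change. The expected step of a number 5.1 percentage points lower from compound 1 to compound 4 (within the scatter) is therefore taken as small and downward, not beyond the scatter. Compound 4 is estimated at 38%, with a range from 22% to 54%.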

Compound 4, a percentage reported as activity, at one dose (the size of the read-out at that dose, not a potency): 44.6%
Estimate against measurement, compound 4: 6.6 percentage points below, and the stated range covers the measured number.
By their numbers in this assay, from the lowest: compounds 3, 2, 1 and 4 (each within the scatter of the next, the first and the last beyond it).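

Going by these compounds alone, replacing carbamoyl with hydrogen on this saturated chain carbon gives a number 1.5 percentage points higher from compound 1 to compound 4 (within the scatter) in this assay and provides the first comparison in this set that differs in only one place. At this single oral dose, the carbamoylmethyl group of compound 1 and the methyl group of compound 4 cannot be told apart, so this read-out shows no need for the carbamoyl group here. No measurement is available to explain this result.

On these data alone, whether an amine, a hydroxymethyl group or a longer chain at this place would also stay within the scatter remains open. A single dose also leaves any difference in potency between compound 1 and compound 4 open.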